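A few compounds are considered here, and "the series" means these few. Any claim that something is new, unique, unknown or untested is made for them only; others in the source may bear on it.

Three compounds share one core and differ only in the chain attached to the oxygen on the aromatic ring. In an assay on isolated protein for agonist activity at Bile acid receptor (Homo sapiens), read by TR-FRET, with a stated time of 3 h, in the absence of a further agent (on this read-out higher numbers stand for an effect only at larger amounts of compound and lower numbers for an effect already at smaller amounts), compound 1 `CCOc1cccc(C(=O)Nc2cccc(C(=O)O)c2)c1` gives 2350 nM, compound 2 `CCCOc1cccc(C(=O)Nc2cccc(C(=O)O)c2)c1` gives 2150 nM, and compound 3 `CC(C)CCOc1cccc(C(=O)Nc2cccc(C(=O)O)c2)c1` gives 2760 nM. Compound 3 stands at the highest of the three numbers, yet the steps of a 1.2-fold higher number from compound 1 to compound 3 (0.07 log units; within the scatter) and a 1.3-fold higher number from compound 2 to compound 3 (0.11 log units; within the scatter) lie within the scatter, as does a 1.1-fold lower number from compound 1 to compound 2 (0.04 log units; within the scatter). Compound 4 `Cc1cccc(COc2cccc(C(=O)Nc3cccc(C(=O)O)c3)c2)c1` brings a change of another kind: 3-methylphenyl in place of isobutyl on a saturated chain carbon bound to an oxygen on an aromatic ring. Going by the values given here, none of the measured steps covers a ring in this place; they only show that lengthening or branching the chain moved nothing beyond the scatter. No direction is expected with confidence. Compound 4 is therefore expected near 2500 nM, between 800 nM and 8000 nM, a step of a 1.1-fold lower number from compound 3 to compound 4 (0.04 log units; within the scatter).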

Compound 4, half-maximal effective concentration: 1860 nM
The estimate for compound 4 lay 1.3-fold (0.13 log units) above the measured number; the measured number falls inside the stated range.
By their numbers in this assay, from the lowest: compounds 4, 2, 1 and 3 (each within the scatter of the next).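

Placing an aromatic ring here, with 3-methylphenyl in place of isobutyl, keeps the number in this assay within the scatter of all three chain compounds (a 1.5-fold lower number from compound 3 to compound 4 (0.17 log units; within the scatter); a 1.2-fold lower number from compound 2 to compound 4 (0.06 log units; within the scatter); a 1.3-fold lower number from compound 1 to compound 4 (0.10 log units; within the scatter)). The earlier compounds shown here covered only saturated chains, and now a ring and those chains give numbers that cannot be told apart at this place.

As far as these compounds go, whether an amine or a carboxylic acid on that ring, in place of the methyl, would move the number beyond the scatter remains open. No further data bear on this result.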